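Propyl for cyclopropyl on the aromatic nitrogen

The source may report more compounds than this note shows. Statements on the series, on what has been measured and on what is new or still open speak of the compounds shown alone.

In an ADME assay on J774.1 cells (Mus musculus) for cytotoxicity, read by resazurin assay, with a stated time of 48 h (on this read-out higher numbers stand for weaker inhibition and lower numbers for stronger inhibition), compound 1 `CCCCn1cc(C(=O)O)c(=O)c2cc(F)c(N3CCC(C(N)=O)CC3)cc21` gives > 100000 nM as a limit of the assay and not a number. Compound 2 `NC(=O)C1CCN(c2cc3c(cc2F)c(=O)c(C(=O)O)cn3C2CC2)CC1` gives > 100000 nM as a limit too, so it holds no numeric place in the series. Both compounds stand at the limit of > 100000 nM in this assay, at which 2 of the 2 values shown sit, and neither offers a number. Compound 3 `CCCn1cc(C(=O)O)c(=O)c2cc(F)c(N3CCC(C(N)=O)CC3)cc21` carries propyl in place of cyclopropyl on an aromatic nitrogen and keeps the shared core. Among the compounds with values here, the one measured step at that nitrogen is a step that the two limits leave unreadable from compound 1 to compound 2 and its size cannot be carried over. Compound 2 at > 100000 nM is the sole anchor for the expectation, and that anchor is a limit. For this assay no step beyond the scatter is expected, and the estimated step is a number no higher from compound 2 to compound 3 (the limit leaves the size open) with neither direction favoured. Compound 3 is estimated at 100000 nM with an expected range from 50000 nM to 200000 nM as working figures.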

Compound 3, half-maximal inhibitory concentration: > 100000 nM
Compound 3: only a limit was reported (the forecaster's own chance of this, stated with the estimate: 90%); the middle value sits exactly at the limit.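

No new step can be read among compound 1, compound 2 and compound 3 in this assay, because all three stand at the same limit of the assay: the limit of > 100000 nM in this assay, at which 3 of the 3 values shown sit.

The compounds shown leave open whether butyl, propyl and cyclopropyl on the aromatic nitrogen differ at all on this read-out.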